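Propyl to cyclopropyl on the aromatic nitrogen

A few compounds are considered here, and "the series" means these few. Any claim that something is new, unique, unknown or untested is made for them only; others in the source may bear on it.

In an ADME assay on J774.1 cells (Mus musculus) for cytotoxicity, read by resazurin assay, with a stated time of 48 h (on this read-out higher numbers stand for weaker inhibition and lower numbers for stronger inhibition), compound 1 (`CCCn1cc(C(=O)NCc2ccc(OC)cc2)c(=O)c2cc(F)c(N3CCC(C(N)=O)CC3)cc21`) reads 41400 nM and compound 2 (`CCCn1cc(C(=O)NCc2ccco2)c(=O)c2cc(F)c(N3CCC(C(N)=O)CC3)cc21`) reads 56900 nM so the pair sits within the scatter, and neither can be ranked over the other. Compound 3 (`NC(=O)C1CCN(c2cc3c(cc2F)c(=O)c(C(=O)NCc2ccco2)cn3C2CC2)CC1`) has cyclopropyl in place of propyl on an aromatic nitrogen and otherwise matches compound 2. Going by the values given here, the only measured step is a 1.4-fold higher number from compound 1 to compound 2 (0.14 log units; within the scatter) and it swaps 4-methoxyphenyl for furan-2-yl, leaving the group on the aromatic nitrogen untouched. It therefore bears only indirectly, and the data hold no direct guide to this change. No shift beyond the scatter is expected in this assay from this swap. The estimated move is a 1.2-fold lower number from compound 2 to compound 3 (0.07 log units; within the scatter) and stays inside the scatter. Compound 3 is expected at 48000 nM with an estimated range of 22000 nM to 100000 nM on this read-out.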

Compound 3, half-maximal inhibitory concentration: > 100000 nM
Compound 3 ended at the assay's limit; the forecaster's own chance of this, stated with the estimate: 20%; middle value at least 2.0-fold (0.31 log units) from the limit.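

In this assay compound 3 gives > 100000 nM, which is a limit of the assay and not a number. This is the only step shown at the group on the aromatic nitrogen, and it reads an at least 1.7-fold higher number from compound 2 to compound 3 (0.24 log units; that floor lies within the scatter), so cyclopropyl in place of propyl gives no sign of a lower number, while the size of any rise remains unfixed. Of the compounds shown, only compound 3 reaches the end of the range: the limit of > 100000 nM in this assay, at which 1 of the 3 values shown sits.

From the compounds shown here alone, whether the true gap between compound 2 and compound 3 lies beyond the scatter remains open, as only a floor is available. Also open, going by these compounds, are how a longer chain such as butyl or a tert-butyl group on the aromatic nitrogen would read in this assay, and whether cyclopropyl behaves alike with the 4-methoxyphenyl group of compound 1.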